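A few compounds are considered here, and "the series" means these few. Any claim that something is new, unique, unknown or untested is made for them only; others in the source may bear on it.

In a functional assay on HCT-116 cells (Homo sapiens) for antiproliferative activity, read by CCK-8 assay, with a stated time of 72 h (a higher number here means a weaker inhibitor, a lower number a stronger inhibitor), compound 2 `CCOc1cc(C(C)(C)C)ccc1C1=NC(c2ccc(Cl)cc2)C(c2ccc(Cl)cc2)N1C(=O)NCCCCCCC(=O)Nc1ccccc1N` gives 10100 nM and stands within the scatter of the other two measured compounds. Compound 1 `CCOc1cc(C(C)(C)C)ccc1C1=NC(c2ccc(Cl)cc2)C(c2ccc(Cl)cc2)N1C(=O)NCCCCCCCC(=O)Nc1ccccc1N` gives 9910 nM and compound 3 `CCOc1cc(C(C)(C)C)ccc1C1=NC(c2ccc(Cl)cc2)C(c2ccc(Cl)cc2)N1C(=O)N1CCC(C(=O)Nc2ccc(/C=C/C(=O)NO)cc2)CC1` gives 9640 nM on the same read-out.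

The step under review leads to compound 4 `CCOc1cc(C(C)(C)C)ccc1C1=NC(c2ccc(Cl)cc2)C(c2ccc(Cl)cc2)N1C(=O)NCCCCC(=O)Nc1ccccc1N` and is described as follows: (2-aminophenyl)carbamoyl in place of 2-((2-aminophenyl)carbamoyl)ethyl on a saturated chain carbon, four bonds along the chain from an amide-type nitrogen. The change sits on a saturated chain carbon, four bonds along the chain from an amide-type nitrogen, and leaves the shared core untouched.

Among the measured compounds shown here, only one measured step bears on it, a change in the same chain: a 1.0-fold higher number from compound 1 to compound 2 (0.01 log units; within the scatter). That step is within the scatter. Compound 3 carries a different linker and says nothing about chain length. For the measured compounds named here, no compound with a chain as short as that of compound 4 has been measured, so the basis is thin.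

No change beyond the scatter is expected in this assay and no direction is assigned. The expected step is a 1.0-fold lower number from compound 2 to compound 4 (0.00 log units; within the scatter) in this estimate. For compound 4 the estimated value is 10000 nM with an expected range from 4500 nM to 20000 nM on this read-out.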

Compound 4, half-maximal inhibitory concentration: 13900 nM
Estimate against measurement, compound 4: 1.4-fold (0.14 log units) below; low and high end bracket the measured number.
By their numbers in this assay, from the lowest: compounds 3, 1, 2 and 4 (each within the scatter of the next).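

In this assay, (2-aminophenyl)carbamoyl in place of 2-((2-aminophenyl)carbamoyl)ethyl on a saturated chain carbon, four bonds along the chain from an amide-type nitrogen, gives a 1.4-fold higher number from compound 2 to compound 4 (0.14 log units; within the scatter). Together with a 1.0-fold higher number from compound 1 to compound 2 (0.01 log units; within the scatter), this means that both steps in this chain lie within the scatter, and compound 4 extends that reading to a shorter chain than the earlier compounds covered. No supporting data on the cells or on the compounds bear on this result.

From the compounds shown here alone, it remains open whether a longer chain than that of compound 1 would give a step beyond the scatter in this assay. The same question stands for a carboxylic acid in place of (2-aminophenyl)carbamoyl, so it is unsettled whether this position can shift the read-out at all.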